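Methoxycarbonyl in Place of Methyl on the Saturated Ring

A few compounds are considered here, and "the series" means these few. Any claim that something is new, unique, unknown or untested is made for them only; others in the source may bear on it.

Among the measured compounds shown here, in an assay (strain Wistar) for inhibition of Fatty-acid amide hydrolase 1 (Rattus norvegicus), read by scintillation counting (on this read-out higher numbers stand for weaker inhibition and lower numbers for stronger inhibition), compound 2 `C[C@@H]1COC(c2cccc(OC(=O)NC3CCCCC3)c2)=N1` gives 16 nM, the lowest of the two numbers measured so far. Compound 1 `C[C@H]1COC(c2cccc(OC(=O)NC3CCCCC3)c2)=N1` gives 51 nM, and the step of a 3.2-fold lower number from compound 1 to compound 2 (0.50 log units; beyond the scatter) arises because of the fact that compounds 1 and 2 differ only in the configuration as drawn. Compound 3 `COC(=O)[C@@H]1COC(c2cccc(OC(=O)NC3CCCCC3)c2)=N1` carries methoxycarbonyl in place of methyl on a saturated ring carbon. For the measured compounds named here, no measured step replaces one group by another at this ring carbon, so the single step from compound 1 to compound 2, a change of configuration alone, offers no guide, and no shift beyond the scatter is assumed. Compound 3 is therefore expected near 25 nM, within 6 nM to 100 nM, which means a 1.6-fold higher number from compound 2 to compound 3 (0.19 log units; within the scatter).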

Compound 3, half-maximal inhibitory concentration: 9.4 nM
For compound 3 the middle estimate is 2.7-fold (0.42 log units) above the measured one; the measured number falls inside the stated range.
By their numbers in this assay, from the lowest: compounds 3 and 2 (each within the scatter of the next); then compound 1.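

The earlier compounds shown here changed only the configuration at this saturated ring carbon, next to the ring nitrogen; here the group itself changes. In this assay, putting methoxycarbonyl, with its 4 heavy atoms and 2 hydrogen-bond acceptors, in place of methyl gives a 1.7-fold lower number from compound 2 to compound 3 (0.23 log units; within the scatter), so the two numbers cannot be told apart and this position tolerates the larger group. Nothing shown here explains the size of this step.

From the compounds shown here alone, whether configuration matters with methoxycarbonyl as it does with methyl remains open. So does the effect of a carboxylic acid or an amine on this ring carbon.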